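The source may hold more compounds than are shown below. What is called first, only, known or untested is meant among the compounds shown, and "the series" means these compounds.

Measured so far, in an assay on Prostate gland for inhibition of steroid 5-alpha-reductase (Rattus norvegicus); on this read-out higher numbers stand for weaker inhibition and lower numbers for stronger inhibition:
- compound 1 `CCCC(C)n1ccc2cc(/C(C)=C/C(=O)Nc3ccccc3OCCCC(=O)O)ccc21`: compound 1 gives 7.8 nM
- compound 2 `CCCCC(CCCC)n1ccc2cc(/C(C)=C/C(=O)Nc3ccccc3OCCCC(=O)O)ccc21`: compound 2 gives 21 nM

Compound 2 stands at the higher of the two numbers, which on this read-out means the weaker inhibition. Among the measured compounds shown here, the one step measured between them, a 2.7-fold higher number from compound 1 to compound 2 (0.43 log units; beyond the scatter), shows that exchanging one branched chain on the aromatic nitrogen for a larger branched chain moved the number upward by a modest but real amount.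

Compound 3 `C/C(=C\C(=O)Nc1ccccc1OCCCC(=O)O)c1ccc2c(ccn2Cc2ccc(C)cc2)c1` is the next variation at the same position: 4-methylbenzyl in place of 1-butylpentyl on an aromatic nitrogen. For the measured compounds named here, the only step that bears on this change is the one from compound 1 to compound 2, and it concerns the size of an open chain rather than a ring bearing group, so it offers limited guidance. The new group is smaller than the one it replaces by the count given, which by that single precedent would point toward a lower number than compound 2. Compound 3 is therefore expected to come in somewhat lower, with a step estimated at a 2.1-fold lower number from compound 2 to compound 3 (0.32 log units; beyond the scatter). The estimated value for compound 3 in this assay is 10 nM, with a plausible range from 3 nM to 35 nM.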

Compound 3, half-maximal inhibitory concentration: 88 nM
Estimate against measurement, compound 3: 8.8-fold (0.94 log units) below; the whole stated range lies below it.
By their numbers in this assay, from the lowest: compound 1; then compound 2; then compound 3.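

In this assay, among the compounds shown here, this result allows the first comparison of a group bearing a ring with open chains on the aromatic nitrogen. The step of a 4.2-fold higher number from compound 2 to compound 3 (0.62 log units; beyond the scatter) brings in 4-methylbenzyl, with 8 heavy atoms against 9 for 1-butylpentyl, yet the number rises and inhibition weakens, so compound 3 goes against the pattern suggested by compound 1 and compound 2, where the group with more heavy atoms gave the higher number. The step of an 11-fold higher number from compound 1 to compound 3 (1.05 log units; beyond the scatter) is the widest gap among these compounds, so across this small set the count of heavy atoms alone does not set the order, and the difference between a branched chain and 4-methylbenzyl matters more than the difference between the two branched chains. Nothing measured here gives a reason for this rise.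

On these data alone, whether the rise belongs to the aromatic ring itself or to the methyl group on it stays open, and a plain benzyl, a 4-chlorobenzyl or a cyclohexylmethyl group on the same nitrogen would help to separate those two questions. Also open, as far as these compounds go, is whether a shorter branched chain, such as isopropyl, would lower the number further or raise it.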